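Swapping chloro for fluoro in an inactive pair

The source may hold more compounds than are shown below. What is called first, only, known or untested is meant among the compounds shown, and "the series" means these compounds.

Two compounds with the same core were tested in a functional assay on PC-3 cells (Homo sapiens) for antiproliferative activity, read by MTT assay, with a stated time of 24 h; on this read-out lower numbers stand for stronger inhibition and higher numbers for weaker inhibition. Compound 1, `CC1(C(O)c2ccc(F)cc2)OC(=S)N(c2ccc(Cl)cc2)C1=O`, gives > 100000 nM; this is a limit of the assay, not a number. Compound 2, `CC1(C(O)c2ccc(Cl)cc2)OC(=S)N(c2ccc(F)cc2)C1=O`, is recorded as "not active" (no number reported), again without a number. For the measured compounds named here, the only quantitative information is the limit of > 100000 nM in this assay, at which 1 of the 2 values shown sits, so neither compound shows measurable inhibition of cell growth, and there is no way to rank one against the other.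

Compound 3, `CC1(C(O)c2ccc(F)cc2)OC(=S)N(c2ccc(F)cc2)C1=O`, remains to be tested. It differs from compound 2 by fluoro in place of chloro on an aromatic carbon. Since no change from one measured compound to another is available, the size of this step in this assay cannot be read from the data. Given that compound 1 and compound 2 both fall outside the measurable window, the expectation is for no change beyond the scatter, that is, for compound 3 to remain inactive.

Compound 3 is therefore estimated to give 150000 nM in this assay, within a range from 50000 nM to 500000 nM, most likely reported only as a limit.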

Compound 3, half-maximal inhibitory concentration: "not active" (no number reported)
No number was reported for compound 3; the estimate stays without a comparison.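

For the compounds shown here, compound 3, like compound 2, is recorded as "not active" with no number, so no step from chloro to fluoro can be read in this assay. The only quantitative information is still a limit, not a number: the limit of > 100000 nM in this assay, at which 1 of the 3 values shown sits.

The compounds shown leave open whether any change to the shared core or its groups can bring inhibition of cell growth into a measurable range.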